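The source may report more compounds than this note shows. Statements on the series, on what has been measured and on what is new or still open speak of the compounds shown alone.

Measured so far:
- Compound 1 `COC(=O)N(C)CC#CCN1CCCC1`: > 10 mg/kg, a limit
- Compound 2 `COC(=O)N(C)CC#CCn1ccnc1`: > 100 mg/kg, a limit

In a functional assay on the whole organism for antagonist activity, with Mus musculus as the target (on this read-out higher numbers stand for an effect only at larger amounts of compound and lower numbers for an effect already at smaller amounts), compound 1 gives > 10 mg/kg. This is a limit, so compound 1 has no exact number, and the same holds for compound 2.

Compound 3 `COC(=O)N(C)C(C)C#CCN1CCCC1` keeps the core of compound 1 with one change methyl in place of hydrogen on a saturated chain carbon bound to an amide-type nitrogen and a triple-bonded carbon.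

Going by the values given here, the only measured step, a step that the two limits leave unreadable from compound 1 to compound 2, changes a different place and has no readable size, so it says little about this methyl. No firm direction is therefore expected, and compound 3 is expected to stay near the limit of compound 1 at > 10 mg/kg. The expected step is a step that the limit leaves unreadable from compound 1 to compound 3. For compound 3 the estimate is 20 mg/kg, with an expected range of 5 mg/kg to 80 mg/kg.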

Compound 3, dose for half-maximal effect: > 100 mg/kg
Compound 3 gave a limit, no number (the forecaster's own chance of this, stated with the estimate: 45%); at least 5.0-fold (0.69 log units) between middle value and limit.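

Compound 1 and compound 3 each give only a limit, and no step can be read between them. The compounds shown leave open whether methyl in place of hydrogen at this place changes the dose needed for half-maximal effect, and in which direction.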